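A few compounds are considered here, and "the series" means these few. Any claim that something is new, unique, unknown or untested is made for them only; others in the source may bear on it.

Measured so far:
compound 1, `Brc1ccc(-c2nc3ncccn3c2Nc2ccccc2)cc1`, in a toxicity assay on A549 cells (Homo sapiens) for cytotoxicity, read by luminescence and CellTiter-Glo, with a stated time of 48 h; a lower number here means that less compound is tolerated, a higher number that more compound is tolerated: > 100000 nM
compound 2, `COCCOc1ccc(-c2nc3ncccn3c2Nc2ccccc2)cc1`, in this assay: > 100000 nM

In this assay compound 1 gives no number of its own but only a limit of the assay, > 100000 nM. Compound 2 likewise gives only a limit, > 100000 nM. For the measured compounds named here, the single measured step, a step that the two limits leave unreadable from compound 1 to compound 2, cannot be read at all, since both ends sit at the same limit (the limit of > 100000 nM in this assay, at which 2 of the 2 values shown sit). Compound 1 thus stands at the edge of what this assay reports, with nothing to rank it against.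

The new compound, compound 3, `Cc1cc(Br)ccc1-c1nc2ncccn2c1Nc1ccccc1`, differs from compound 1 by methyl in place of hydrogen on an aromatic carbon. Going by the values given here, no measured step touches a methyl, and the one step that exists has no readable size, so there is no measured basis for expecting a shift in either direction. The expectation is that compound 3 also stays at or beyond the edge of the assay, with an estimated value of 150000 nM, expected to lie between 40000 nM and 500000 nM. For compound 3 this means an expected step that the limit leaves unreadable from compound 1 to compound 3, that is, nothing beyond the usual scatter.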

Compound 3, half-maximal cytotoxic concentration: 40000 nM
Estimate against measurement, compound 3: 3.8-fold (0.57 log units) above, within the range that was stated.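

In this assay, for the compounds shown here, compound 3 is the first of the three compounds to give a number of its own, 40000 nM, so the series now has a reading inside the range the assay reports. Placing a methyl on an aromatic carbon, ortho to a large group, gives an at least 2.5-fold lower number from compound 1 to compound 3 (0.39 log units; beyond the scatter), which shows that this place on the ring responds to even a very small addition, in the direction of less compound being tolerated. The full size of this step stays unknown because compound 1 gives only a limit:  the limit of > 100000 nM in this assay, at which 2 of the 3 values shown sit.

The compounds shown leave open whether this shift is particular to methyl or would also appear with an ethyl group, a chlorine atom or a hydroxyl group at the same place, and whether it would persist with the 2-methoxyethoxy group of compound 2 in place of bromo. As far as these compounds go, the step between compound 1 and compound 2 cannot be read, so the effect of changing the bromo group also remains open.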